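A few compounds are considered here, and "the series" means these few. Any claim that something is new, unique, unknown or untested is made for them only; others in the source may bear on it.

Measured in a functional assay on Jurkat cells (Homo sapiens) for inhibition, read by CCK-8 assay, with a stated time of 48 h; a lower number here means a stronger inhibitor of growth, a higher number a weaker inhibitor of growth:
- compound 1 `Cc1ccccc1Nc1nc(Nc2ccccn2)ncc1Cl`: 20100 nM
- compound 2 `Cc1ccccc1Nc1nc(Nc2ccc(N3CCCN(C)CC3)cc2)ncc1Cl`: 11300 nM
- compound 3 `CN1CCN(c2ccc(Nc3ncc(Cl)c(Nc4ccccc4)n3)nc2)CC1`: > 100000 nM, a limit and not a number

Compound 3 gives no number, and its reading is the limit of > 100000 nM in this assay, at which 1 of the 3 values shown sits. Compound 4 `CN1CCN(c2ccc(Nc3ncc(Cl)c(NCc4ccco4)n3)nc2)CC1` carries (furan-2-yl)methyl in place of phenyl on a nitrogen on an aromatic ring. Within the data shown here, no measured step shows what such a change does. Among the measured compounds shown here, the only numbers available are those of compound 1 at 20100 nM and compound 2 at 11300 nM, so a modest move toward stronger growth inhibition in this assay is expected. A second reading at the limit would be no surprise. The expected change is an at least 2.2-fold lower number from compound 3 to compound 4 (0.34 log units; beyond the scatter). For compound 4 the estimate is 45000 nM, with an expected range from 12000 nM to 100000 nM.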

Compound 4, concentration for 50% growth inhibition: > 100000 nM
Compound 4: no number, only a limit (the forecaster's own chance of this, stated with the estimate: 35%); at least 2.2-fold (0.34 log units) between middle value and limit.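

Among these compounds, compound 3 and compound 4 both give only limits and not numbers, so no step between them can be read: the limit of > 100000 nM in this assay, at which 2 of the 4 values shown sit. The compounds shown leave open whether (furan-2-yl)methyl in place of phenyl on a nitrogen on an aromatic ring changes growth inhibition at all.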